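From methoxy to hydroxy: compound 3 to compound 4

A few compounds are considered here, and "the series" means these few. Any claim that something is new, unique, unknown or untested is made for them only; others in the source may bear on it.

The compounds measured so far in a functional assay on BV-2 cells (Mus musculus) for inhibition, read by Griess assay, with a stated time of 24 h (a higher number here means a weaker inhibitor, a lower number a stronger inhibitor), are these
- Compound 1 `C=CCn1ccc(-c2cc(Br)ccc2O)n1` gives 112000 nM
- Compound 2 `C=CCn1ccc(-c2cc(Br)ccc2OC)n1` gives > 200000 nM (a limit, not a number)
- Compound 3 `C=CCc1ccc(OC)c(-c2ccn(CC=C)n2)c1` gives > 200000 nM (a limit, not a number)

Compound 3 stands at the limit of > 200000 nM in this assay, at which 2 of the 3 values shown sit, and so has no exact number. Compound 4 `C=CCc1ccc(O)c(-c2ccn(CC=C)n2)c1` makes one change to it, hydrogen in place of methyl on an oxygen on an aromatic ring, which is methoxy to hydroxy. On these data alone, the nearest measured step is this same exchange in reverse (an at least 1.7-fold higher number from compound 1 to compound 2 (0.25 log units; that floor lies within the scatter)), and its true size stays open. The other step (a step that the two limits leave unreadable from compound 2 to compound 3) is allyl in place of bromo and gives no size at all. In this assay, among the compounds with values here, a modest fall in the number is therefore expected, resting on compound 1 with its hydroxy at 112000 nM as the only real number. The expected move is an at least 1.8-fold lower number from compound 3 to compound 4 (0.25 log units; that floor lies within the scatter) as a rough estimate. For compound 4 the expected value is 110000 nM with 50000 nM to 200000 nM as the estimated range.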

Compound 4, half-maximal inhibitory concentration: 1200 nM
For compound 4 the middle estimate is 92-fold (1.96 log units) above the measured one; measured number outside the range, below it.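

In this assay, the methoxy to hydroxy change on the allyl-bearing core gives an at least 160-fold lower number from compound 3 to compound 4 (2.22 log units; beyond the scatter), so on this core a free hydroxy on the aromatic ring turns a compound stuck at a limit into one with a real number. The earlier pair could not show a change of this size, and the two cores can still not be told apart on this point: the same change on two cores in this assay, an at least 1.7-fold higher number (0.25 log units; that floor lies within the scatter) from compound 1 to compound 2 and an at least 160-fold higher number (2.22 log units; beyond the scatter) from compound 4 to compound 3; the limit leaves it open whether they differ. Within the data shown here, the allyl in place of bromo change also becomes readable for the first time, now between two hydroxy compounds, with a 93-fold lower number from compound 1 to compound 4 (1.97 log units; beyond the scatter), so the group on that aromatic carbon matters too when the hydroxy is present.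

The same change between the two methoxy compounds, compound 2 and compound 3, cannot be read, as both stand at a limit: the limit of > 200000 nM in this assay, at which 2 of the 4 values shown sit. Also open, on these data alone, is what other groups would do at these places, such as an amine in place of the hydroxy or a longer chain in place of the allyl.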